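The source may hold more compounds than are shown below. What is called first, only, known or untested is meant among the compounds shown, and "the series" means these compounds.

Compounds measured:
compound 1 `O=C(COC(=O)C#Cc1ccccc1)NCCC[Te]c1ccccc1` — 7000 nM
compound 2 `COc1ccc(N(CC(=O)NCCCSc2ccccc2)C(=O)CCSC2=C(C)C(=O)c3ccccc3C2=O)cc1` — 26000 nM
compound 3 `COc1ccc(N(CC(=O)NCCC[Te]c2ccccc2)C(=O)/C=C/c2ccccc2)cc1` — 5000 nM

In an ADME assay on cells (Fibroblast, Homo sapiens) for cytotoxicity, read by MTT assay, with a stated time of 24 h (on this read-out higher numbers stand for weaker inhibition and lower numbers for stronger inhibition), compound 2 gives the highest number of the three, beyond the scatter of both compound 1, the nearest, and compound 3, the furthest. Compound 4 `COc1ccc(N(CC(=O)NCCC[Te]c2ccccc2)C(=O)CCSC2=C(C)C(=O)c3ccccc3C2=O)cc1` differs from compound 2 in one place: a group of 7 heavy atoms (6 carbon, 1 tellurium; one six-membered aromatic ring of carbon only) in place of a group of 7 heavy atoms (6 carbon, 1 sulfur; one six-membered aromatic ring of carbon only), on a saturated chain carbon, three bonds along the chain from an amide-type nitrogen. Going by the values given here, no measured pair isolates this change, and compounds 1 and 3 differ from compound 2 in more places than this one, so their lower numbers give only a loose hint. Compound 4 is expected to sit somewhat below compound 2, the step from compound 2 to compound 4 estimated at a 2.2-fold lower number from compound 2 to compound 4 (0.34 log units; beyond the scatter), with a fair chance it stays within the scatter. Compound 4 is thus estimated at 12000 nM, between 4500 nM and 32000 nM.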

Compound 4, half-maximal inhibitory concentration: 4000 nM
Compound 4: the middle estimate sits 3.0-fold (0.48 log units) above what was measured; measured number outside the range, below it.
By their numbers in this assay, from the lowest: compounds 4, 3 and 1 (each within the scatter of the next); then compound 2.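

In this assay, going by these compounds alone, this pair gives the first isolated reading of the change: tellurium in place of the sulfur of phenylsulfanyl, on a saturated chain carbon, three bonds along the chain from an amide-type nitrogen, gives a 6.5-fold lower number from compound 2 to compound 4 (0.81 log units; beyond the scatter) and lies beyond the scatter. Within the data shown here, compounds 1 and 3 also carry tellurium, but neither has a sulfur partner, so only this pair isolates the change. Nothing shown here accounts for the step. On these data alone, it remains open how a phenylselanyl group, with selenium in the same place, would read. Also open, as far as these compounds go, is whether the step would persist with a longer chain leading to that atom.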